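From 4-hydroxypiperidin-1-yl to 3-hydroxyazetidin-1-yl on a carbonyl

The source may report more compounds than this note shows. Statements on the series, on what has been measured and on what is new or still open speak of the compounds shown alone.

In a functional assay on A20 cells (Mus musculus) for inhibition, with stated times of 1 h, 16 h and 24 h (a lower number here means a stronger inhibitor, a higher number a weaker inhibitor), compound 1 (`C[C@@H]1CN(C(=O)[C@@H]2C[C@H](S(=O)(=O)c3ccccc3)C[C@H]2C(=O)NC2(C#N)CC2)C[C@H](C)O1`) gives 1 nM, while compound 2 (`N#CC1(NC(=O)[C@@H]2C[C@@H](S(=O)(=O)c3ccccc3)C[C@H]2C(=O)N2CCC(O)CC2)CC1`) gives 371 nM, the higher of the two numbers and so the weaker inhibitor of the pair. Compound 3 (`N#CC1(NC(=O)[C@@H]2C[C@@H](S(=O)(=O)c3ccccc3)C[C@H]2C(=O)N2CC(O)C2)CC1`) has not yet been measured. It departs from compound 2 in one place, on a carbonyl carbon: 3-hydroxyazetidin-1-yl in place of 4-hydroxypiperidin-1-yl on a carbonyl carbon. Among the compounds with values here, only one measured step bears on this change, a 370-fold higher number from compound 1 to compound 2 (2.57 log units; beyond the scatter), and it lies at a carbonyl carbon too. That large step shows that the group held there can move the number a long way in this assay. It brought in 4-hydroxypiperidin-1-yl for 2,6-dimethylmorpholin-4-yl, whereas here one hydroxy-bearing ring gives way to another, so a much smaller step is expected. Within the data shown here, a modest rise in the number seems slightly more likely, though no measurement yet tests this exchange and its direction remains uncertain. The expected change is a 1.3-fold higher number from compound 2 to compound 3 (0.13 log units; within the scatter). For compound 3 the estimated value is 500 nM, with an expected range from 150 nM to 1700 nM.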

Compound 3, half-maximal inhibitory concentration: 572 nM
The estimate for compound 3 lay 1.1-fold (0.06 log units) below the measured number, and the stated range covers the measured number.
By their numbers in this assay, from the lowest: compound 1; then compounds 2 and 3 (each within the scatter of the next).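

In this assay, putting 3-hydroxyazetidin-1-yl in place of 4-hydroxypiperidin-1-yl on the carbonyl carbon gives a 1.5-fold higher number from compound 2 to compound 3 (0.19 log units; within the scatter), so these two hydroxy-bearing groups, one with a six-membered ring and one with a four-membered ring, cannot be told apart at this position. The wide gap to the dimethylmorpholine compound therefore does not belong to 4-hydroxypiperidin-1-yl alone, since replacing 2,6-dimethylmorpholin-4-yl with 3-hydroxyazetidin-1-yl gives a 570-fold higher number from compound 1 to compound 3 (2.76 log units; beyond the scatter), a step that, like the earlier one, is large and beyond the scatter. Nothing available explains either step or ties it to any feature of these groups.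

The compounds shown leave open which part of 2,6-dimethylmorpholin-4-yl goes with the low number of compound 1, as all that stands against it are two rings that carry a hydroxy group and lack the methyl groups and the ring oxygen. Whether a plain morpholin-4-yl, a 2,6-dimethylpiperidin-1-yl or a piperidin-1-yl without its hydroxy group would fall near compound 1 or near compound 2 and compound 3 remains an open question.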